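The source may report more compounds than this note shows. Statements on the series, on what has been measured and on what is new or still open speak of the compounds shown alone.

Two compounds open the story. Compound 1 `O=C(NC1CCN(Cc2ccc(OC3CCNCC3)c(Br)c2)CC1)c1cc2cc(Cl)ccc2s1` carries a chloro on an aromatic carbon of the shared core, and in an assay on HEK293 cells for displacement of a labelled ligand from Urotensin-2 receptor (Homo sapiens), read by fluorescence, with a stated time of 90 min (on this read-out higher numbers stand for weaker inhibition and lower numbers for stronger inhibition), compound 1 gives 51 nM. Compound 2 `O=C(NC1CCN(Cc2ccc(OC3CCNCC3)c(Br)c2)CC1)c1cc2cc(Br)ccc2s1` carries a bromo on that same aromatic carbon, and in this assay compound 2 gives 86 nM. Among the compounds with values here, the only measured step, a 1.7-fold higher number from compound 1 to compound 2 (0.23 log units; within the scatter), stays inside the scatter, so compound 2 stands alongside compound 1: its number is the one that reads higher of the two, but the gap is no real difference.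

Compound 3 `O=C(NC1CCN(Cc2ccc(OC3CCNCC3)c(Br)c2)CC1)c1cc2cc(C(F)(F)F)ccc2s1` continues from compound 2 with a change at the same aromatic carbon: trifluoromethyl in place of bromo on an aromatic carbon. Within the data shown here, the single step that bears on it is a 1.7-fold higher number from compound 1 to compound 2 (0.23 log units; within the scatter), which exchanged one small group for another at this place and moved the number only within the scatter. Among the measured compounds shown here, with that one step as the sole guide, the expected step of a 1.1-fold higher number from compound 2 to compound 3 (0.04 log units; within the scatter) is small and has no clear direction beyond the scatter. For compound 3 the estimate in this assay is 95 nM, with a range from 35 nM to 260 nM.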

Compound 3, half-maximal inhibitory concentration: 100 nM
The estimate for compound 3 lay 1.1-fold (0.02 log units) below the measured number, within the range that was stated.
By their numbers in this assay, from the lowest: compounds 1, 2 and 3 (each within the scatter of the next).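

Compound 3 shows that this aromatic carbon can take a group of 4 heavy atoms as readily as one of 1 heavy atom in this assay: trifluoromethyl in place of bromo gives a 1.2-fold higher number from compound 2 to compound 3 (0.07 log units; within the scatter), and trifluoromethyl in place of chloro gives a 2.0-fold higher number from compound 1 to compound 3 (0.29 log units; within the scatter). Both steps lie within the scatter, so the earlier finding that exchanging chloro for bromo changes little now extends to a group that is not a single atom, and the three compounds cannot be ranked against one another. Nothing available here explains why the number stays so flat at this position.

Bromo and trifluoromethyl both count no hydrogen-bond donors, no hydrogen-bond acceptors and no net charge, so the compounds shown leave open whether the number would hold with an amine, a carboxylic acid or a longer chain on this carbon. They also leave open whether changes at other places on the shared core would be met with the same flatness.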